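Amide Variation and Volume of Distribution in Rat

The source may report more compounds than this note shows. Statements on the series, on what has been measured and on what is new or still open speak of the compounds shown alone.

Measured compounds:
compound 1, `COc1cc(F)ccc1-c1ccnc2[nH]c(C3CCN(CC(=O)N(C)C)CC3)cc12`, 2.3 L/kg
compound 2, `CC(C)n1cc(-c2ccnc3[nH]c(C4CCN(CC(=O)N5CCCC5)CC4)cc23)ccc1=O`, 3.9 L/kg

Both were dosed in an ADME assay (Rattus norvegicus, strain Han-wistar) for pharmacokinetics, at a dose of 1.5 umol/kg by the intravenous route; on this read-out lower numbers stand for narrower distribution and higher numbers for wider distribution into tissues. Compound 2 holds the higher of the two numbers, while compound 1 sits a little lower, yet the gap between them lies within the scatter of this assay, so the two cannot be ordered.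

The unmeasured compound 3, `CC(C)n1cc(-c2ccnc3[nH]c(C4CCN(CC(=O)N(C)C)CC4)cc23)ccc1=O`, shares its core with compound 2 and differs from it at a single site on the amide: dimethylamino in place of pyrrolidin-1-yl on a carbonyl carbon. Among the compounds with values here, no pair of measured compounds differs in this place alone, so no measured step tells what this change does. Compound 1 also carries a dimethylcarbamoyl group but differs from compound 3 elsewhere, so it serves only as a loose guide.

Compound 3 is therefore expected to show a small step down, a 1.3-fold lower number from compound 2 to compound 3 (0.11 log units; within the scatter), which stays within the scatter. The volume of distribution of compound 3 is estimated at 3 L/kg, with a range from 1.8 L/kg to 5 L/kg.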

Compound 3, volume of distribution: 5.9 L/kg
Compound 3: middle estimate off by 2.0-fold (0.29 log units), on the low side; the measured number lies above the stated range.
By their numbers in this assay, from the lowest: compounds 1, 2 and 3 (each within the scatter of the next, the first and the last beyond it).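

In this assay, the site on the carbonyl carbon now has a measured step: dimethylamino in place of pyrrolidin-1-yl gives a 1.5-fold higher number from compound 2 to compound 3 (0.18 log units; within the scatter), so within the scatter of this read-out the two amides cannot be told apart, and this single pair offers no sign that the site matters. With the dimethylcarbamoyl group held constant, the other new step reads a different place, an aromatic carbon, where a group of 10 heavy atoms with a six-membered aromatic ring holding 1 hetero atom stands in place of a group of 9 heavy atoms with a six-membered aromatic ring of carbon only, and it gives a 2.6-fold higher number from compound 1 to compound 3 (0.41 log units; beyond the scatter), a modest step but the only one shown beyond the scatter. Nothing measured here accounts for either step.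

The compounds shown leave open how a morpholin-4-yl group or a primary amide on the same carbonyl carbon would read. They also leave open whether the step on the aromatic carbon would hold with pyrrolidin-1-yl on the amide.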